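This account rests on a few compounds, and the source may have more. Where it says the series, first, only, none or still open, it means among the compounds named here.

Measured compounds:
- Compound 1, `Cc1nccn1-c1cnc(NCc2c(F)ccc3c2CCO3)c2cn[nH]c(=O)c12`: 7000 nM
- Compound 2, `CNC(=O)c1cc(-c2cnc(NCc3c(F)ccc4c3CCO4)c3cn[nH]c(=O)c23)n(C)n1`: 7000 nM
- Compound 3, `O=C1CCCN1c1cnc(NCc2c(F)ccc3c2CCO3)c2cn[nH]c(=O)c12`: < 2000 nM

Of the compounds shown here, three sharing one core have been measured in a physicochemical assay for solubility, read by LC-MS, in phosphate buffer, with a stated time of 24 h, at pH 7.4; on this read-out lower numbers stand for lower solubility and higher numbers for higher solubility. Compound 1 gives 7000 nM, and compound 2 gives 7000 nM; the step of no change at the digits printed from compound 1 to compound 2 (within the scatter). Compound 3 gives < 2000 nM, which is a limit of the assay rather than a number. Compound 3 therefore stands at the limit of < 2000 nM in this assay, at which 1 of the 3 values shown sits, and its exact position cannot be fixed.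

Compound 4, `Cc1ncc(-c2cnc(NCc3c(F)ccc4c3CCO4)c3cn[nH]c(=O)c23)n1C`, has not yet been measured. It differs from compound 3 in one place: 1,2-dimethyl-1H-imidazol-5-yl in place of 2-oxopyrrolidin-1-yl on an aromatic carbon. Among the compounds with values here, the steps that bear on this are an at least 3.5-fold lower number from compound 1 to compound 3 (0.54 log units; beyond the scatter) and an at least 3.5-fold lower number from compound 2 to compound 3 (0.54 log units; beyond the scatter); in both of them 2-oxopyrrolidin-1-yl enters. Compound 4 instead carries 1,2-dimethyl-1H-imidazol-5-yl, an imidazole like the 2-methyl-1H-imidazol-1-yl of compound 1. The change from compound 3 to compound 4 is therefore expected to go the opposite way, upward, by at least a modest step, an at least 3.0-fold higher number from compound 3 to compound 4 (0.47 log units; beyond the scatter). Compound 4 is estimated to give 6000 nM, with a range from 2000 nM to 20000 nM.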

Compound 4, solubility: 15000 nM
The estimate for compound 4 lay 2.5-fold (0.40 log units) below the measured number, within the range that was stated.
By their numbers in this assay, from the lowest: compounds 1 and 2 (each within the scatter of the next); then compound 4. At a limit, below all of these: compound 3.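

In this assay, the entering 1,2-dimethyl-1H-imidazol-5-yl group, on the aromatic carbon para to a large group, puts compound 4 above both earlier aromatic-ring compounds, with a 2.1-fold higher number from compound 1 to compound 4 (0.33 log units; beyond the scatter) and a 2.1-fold higher number from compound 2 to compound 4 (0.33 log units; beyond the scatter); these modest steps show that aromatic five-membered rings at this position need not all read alike, which the matching values of compound 1 and compound 2 could not show. Within the data shown here, replacing the non-aromatic 2-oxopyrrolidin-1-yl ring with this imidazole gives the largest change seen at this position so far, an at least 7.5-fold higher number from compound 3 to compound 4 (0.87 log units; beyond the scatter), and this size is only a lower bound. Compound 3 is held at a limit of the assay, not at a number: the limit of < 2000 nM in this assay, at which 1 of the 4 values shown sits.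

The compounds shown do not tell which feature of the entering group matters, for instance its two methyl groups or its attachment through ring carbon rather than the ring nitrogen used in compound 1, and they give no cause for the steps. As far as these compounds go, how an amine or a carboxylic acid on this same aromatic carbon would read in this assay remains open.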